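Swapping the benzyl substituent of compound 1

This account rests on a few compounds, and the source may have more. Where it says the series, first, only, none or still open, it means among the compounds named here.

Compound 1 `CN(CCCCn1c(=O)oc2ccccc21)Cc1cccc(Cl)c1` gives 302 nM in an assay on membranes from liver for displacement of a labelled ligand from Sigma non-opioid intracellular receptor 1 (Rattus norvegicus), read by scintillation counting; on this read-out higher numbers stand for weaker inhibition and lower numbers for stronger inhibition. Among the three measured compounds it holds the second highest number; its nearest neighbour is compound 3 `CN(CCCn1c(=O)oc2ccccc21)Cc1ccccc1` with 223 nM, a gap within the scatter, and its furthest is compound 2 `CN(CCCn1c(=O)oc2ccccc21)Cc1ccc(Cl)cc1` with 1150 nM, a gap beyond the scatter. Compound 2 and compound 3 carry a shorter chain than compound 1 and differ from one another only on the aromatic ring; a 5.2-fold lower number from compound 2 to compound 3 (0.71 log units; beyond the scatter). Within the data shown here, no single-change step links compound 1 to either of them, so those two values can only be read side by side with it.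

The unmeasured compound 4 `Cc1ccc(CN(C)CCCCn2c(=O)oc3ccccc32)cc1` arises from compound 1 by 4-methylphenyl in place of 3-chlorophenyl on a saturated chain carbon bound to an amine nitrogen. Among the measured compounds shown here, only the step from compound 2 to compound 3 bears on this change, and only in part: it shows that losing a chloro from the ring lowered the number on the shorter chain, whereas compound 4 keeps a substituent on the ring and merely exchanges it. For the measured compounds named here, because compound 1 sits at 302 nM and the one comparable step was modest, the expected step is small or none beyond the scatter, a 1.3-fold higher number from compound 1 to compound 4 (0.12 log units; within the scatter). Compound 4 is therefore estimated at 400 nM, within a range from 120 nM to 1500 nM.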

Compound 4, inhibition constant: 97 nM
Compound 4: the middle estimate sits 4.1-fold (0.62 log units) above what was measured; the whole stated range lies above it.
By their numbers in this assay, from the lowest: compound 4; then compounds 3 and 1 (each within the scatter of the next); then compound 2.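

In this assay, putting 4-methylphenyl in place of 3-chlorophenyl on a saturated chain carbon bound to an amine nitrogen gives a 3.1-fold lower number from compound 1 to compound 4 (0.49 log units; beyond the scatter) and moves the number beyond the scatter. The earlier step, a 5.2-fold lower number from compound 2 to compound 3 (0.71 log units; beyond the scatter) on the shorter chain, showed only what happened when a chloro was replaced by hydrogen; this result shows that exchanging one substituted ring for another can also shift the number clearly, with the ring still carrying a substituent. The two steps differ in both chain and change, so their sizes cannot be set against one another, and nothing shown gives a measured reason for the new step.

Compound 4 differs from compound 1 in both the kind of substituent and the name of the ring that carries it, leaving open how much of the step belongs to the methyl group, to the loss of the chloro or to the change from 3-substituted to 4-substituted phenyl. Also open, on these data alone, is how a methoxy group or a fluoro on this ring would read on the chain of compound 4, and whether a longer chain would keep the step.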